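Removing the methyl from the benzyl group of compound 1

The source may report more compounds than this note shows. Statements on the series, on what has been measured and on what is new or still open speak of the compounds shown alone.

Compound 1 `Cc1cccc(Cn2cc(COc3ccc4c(=O)ccoc4c3)nn2)c1` carries a 3-methylbenzyl group on the triazole of the shared core. Within the data shown here, in a functional assay on SW480 cells (Homo sapiens) for cytotoxicity, read by MTT assay, with a stated time of 48 h (on this read-out lower numbers stand for stronger inhibition and higher numbers for weaker inhibition), compound 1 gives 11700 nM, the only plain number among the three measured compounds. Compound 2 `O=c1ccoc2cc(OCc3cn(Cc4cccc(F)c4)nn3)ccc12` reaches only the limit of the assay, > 100000 nM. Compound 3 `O=c1ccoc2cc(OCc3cn(Cc4ccccc4Br)nn3)ccc12` likewise stops at the limit, > 100000 nM. Both other measured values therefore sit at the limit described by the limit of > 100000 nM in this assay, at which 2 of the 3 values shown sit.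

Compound 4 `O=c1ccoc2cc(OCc3cn(Cc4ccccc4)nn3)ccc12` differs from compound 1 by hydrogen in place of methyl on an aromatic carbon. Among the measured compounds shown here, two measured steps bear on this change: an at least 8.5-fold higher number from compound 1 to compound 2 (0.93 log units; beyond the scatter) and an at least 8.5-fold higher number from compound 1 to compound 3 (0.93 log units; beyond the scatter). Both alterations of the 3-methylphenyl group of compound 1 pushed the number to the limit, so the methyl appears to matter for the read-out of compound 1, although neither step is an exact match for simply taking the methyl away.

Compound 4 is therefore expected to give a clearly higher number, a step of a 5.1-fold higher number from compound 1 to compound 4 (0.71 log units; beyond the scatter), with a fair chance that only a limit is returned. The estimate for compound 4 is 60000 nM, within a range of 15000 nM to 200000 nM.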

Compound 4, half-maximal inhibitory concentration: 42900 nM
Estimate against measurement, compound 4: 1.4-fold (0.15 log units) above, within the range that was stated.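

Taking the methyl away leaves a plain number in this assay rather than a limit, and the change now has a size of its own (a 3.7-fold higher number from compound 1 to compound 4 (0.56 log units; beyond the scatter)). The methyl therefore accounts for only part of what separates compound 1 from the halogen-bearing compounds, since the benzyl compound also stands apart from them (an at least 2.3-fold lower number from compound 3 to compound 4 (0.36 log units; beyond the scatter); an at least 2.3-fold lower number from compound 2 to compound 4 (0.36 log units; beyond the scatter)). Among these compounds, a bromo or fluoro in place of hydrogen goes with a higher number, yet how much higher stays unknown, as compound 2 and compound 3 each give only a limit and not a number: the limit of > 100000 nM in this assay, at which 2 of the 4 values shown sit.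

Going by these compounds, whether a methoxy or an amine in place of the methyl would hold or lower the number of compound 1 remains open. So does the effect of a longer chain, such as ethyl, on the same aromatic carbon.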